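Notes on compound 4 against compound 1

The source may hold more compounds than are shown below. What is called first, only, known or untested is meant among the compounds shown, and "the series" means these compounds.

In a functional assay on SK-BR-3 cells (Homo sapiens) for antiproliferative activity, read by MTT assay, with a stated time of 72 h (on this read-out lower numbers stand for stronger inhibition and higher numbers for weaker inhibition), compound 1 `Cc1cc(NCCN(C)C)nc2ccc(NC(=O)c3ccc(Cl)c(Cl)c3)cc12` gives 6670 nM, the lowest of the three numbers in hand, with compound 2 `CCN1CCN(c2cc(C)c3cc(NC(=O)c4ccc(OC)cc4)ccc3n2)CC1` at 9000 nM and compound 3 `CCN1CCN(c2cc(C)c3cc(NC(=O)c4cccnc4)ccc3n2)CC1` at 10600 nM; all three sit within the scatter of one another. Compound 4 `Cc1cc(N2CCCC2)nc2ccc(NC(=O)c3ccc(Cl)c(Cl)c3)cc12` differs from compound 1 in one place: pyrrolidin-1-yl in place of (2-(dimethylamino)ethyl)amino on an aromatic carbon. Among the measured compounds shown here, no measured step touches this position. For the measured compounds named here, the only single-point step known, a 1.2-fold higher number from compound 2 to compound 3 (0.07 log units; within the scatter), concerns the group on the carbonyl carbon and says nothing about the group on the aromatic carbon; compounds 2 and 3 differ from compound 1 in more than one place, so their values give no step for this change. With nothing pointing either way, no step beyond the scatter is expected, a 1.0-fold higher number from compound 1 to compound 4 (0.02 log units; within the scatter). Compound 4 is therefore estimated at 7000 nM, in the range 2500 nM to 20000 nM.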

Compound 4, half-maximal inhibitory concentration: 43400 nM
Compound 4: middle estimate off by 6.2-fold (0.79 log units), on the low side; measured number outside the range, above it.
By their numbers in this assay, from the lowest: compounds 1, 2 and 3 (each within the scatter of the next); then compound 4.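

In this assay, among the compounds shown here, this position is not neutral: pyrrolidin-1-yl in place of (2-(dimethylamino)ethyl)amino gives a 6.5-fold higher number from compound 1 to compound 4 (0.81 log units; beyond the scatter), the only step beyond the scatter. The change removes the open chain with its dimethylamino end and its hydrogen-bond donor, and closes a ring on the aromatic carbon, all in one step. No measurement on hand accounts for this step.

Which of these differences carries the step remains open. A plain ethylamino group or a longer 3-(dimethylamino)propylamino chain at this position would help separate them.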